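A few compounds are considered here, and "the series" means these few. Any claim that something is new, unique, unknown or untested is made for them only; others in the source may bear on it.

Compound 1 `Fc1ccc(-c2csc(N/N=C/c3ccc(-n4ccnc4)cc3)n2)cc1`, compound 2 `Clc1ccc(-c2csc(N/N=C/c3ccc(-n4ccnc4)cc3)n2)cc1` and compound 3 `Cc1ccc(-c2csc(N/N=C/c3ccc(-n4ccnc4)cc3)n2)cc1` share one core and differ only in the group on an aromatic carbon. In an ADME assay on THP-1 cells (Homo sapiens) for cytotoxicity, read by MTT assay, tested at 50 ug/mL (a higher number here means more inhibition at the concentration tested (going by the name of the read-out), a lower number less inhibition), compound 1 gives 18.7%, compound 2 gives 32.1% and compound 3 gives 36%, the highest of the three numbers; the nearest is a number 3.9 percentage points higher from compound 2 to compound 3 (within the scatter), within the scatter, and the furthest is a number 17.3 percentage points higher from compound 1 to compound 3 (beyond the scatter), beyond it. Compound 4 `COc1ccc(-c2csc(N/N=C/c3ccc(-n4ccnc4)cc3)n2)cc1` arises from compound 3 by methoxy in place of methyl on an aromatic carbon, para to a large group. The changes of the same kind were a number 13.4 percentage points higher from compound 1 to compound 2 (beyond the scatter) and a number 17.3 percentage points higher from compound 1 to compound 3 (beyond the scatter), both modest, while a number 3.9 percentage points higher from compound 2 to compound 3 (within the scatter) stayed within the scatter. No measured change involves methoxy, so at most a modest step is expected, a number 2 percentage points lower from compound 3 to compound 4 (within the scatter). Compound 4 is therefore expected to give 34% in this assay, between 20% and 48%.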

Compound 4, a percentage reported as inhibition, at one concentration (the size of the read-out at that concentration, not a potency): 26.8%
The estimate for compound 4 lay 7.2 percentage points above the measured number; the measured number falls inside the stated range.
By their numbers in this assay, from the lowest: compounds 1, 4, 2 and 3 (each within the scatter of the next, the first and the last beyond it).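

In this assay methoxy on this aromatic carbon gives a number 9.2 percentage points lower from compound 3 to compound 4 (within the scatter) and a number 5.3 percentage points lower from compound 2 to compound 4 (within the scatter) and also a number 8.1 percentage points higher from compound 1 to compound 4 (within the scatter) in this small series. Methoxy thus cannot be told apart from methyl, chloro or fluoro here, although fluoro was separated from both chloro and methyl by the earlier steps. Nothing available explains this result. The compounds shown leave open how an amine or a carboxylic acid would read at this position. They also leave open whether a longer chain, such as ethoxy in place of methoxy, would read differently.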